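The compounds below may be only part of what the source reports. "The series", "measured", "known", "first", "only" and "open" are said of these compounds alone.

Working notes on the series. All three compounds share one core. In an in vitro functional assay on cells for agonist activity at Bombesin receptor subtype-3 (Mus musculus), read by luminescence and calcium flux (on this read-out lower numbers stand for an effect already at smaller amounts and higher numbers for an effect only at larger amounts of compound), compound 1 `N#Cc1ccc(Cc2cnc(CCc3ccc(-c4ccccc4C(=O)O)cc3)[nH]2)cc1` gives 723 nM, the lowest of the two numbers at hand. Compound 2 `CCCCc1cnc(/C=C/c2ccc(-c3ccccc3C(=O)O)cc2)[nH]1` gives 10000 nM in this assay, a gap to compound 1 that lies beyond the scatter. Compound 3 `Cc1ccc(Cc2cnc(CCc3ccc(-c4ccccc4C(=O)O)cc3)[nH]2)cc1` is compound 1 with one change: methyl in place of cyano on an aromatic carbon. Among the measured compounds shown here, no measured pair covers this change, so its size is open; the only guide is that compound 1 carries the lowest number so far and that another change of the arm, in compound 2, moved the number up. A modest rise is expected rather than a gain. Compound 3 is estimated at 2000 nM, within 700 nM to 6000 nM. The expected step is a 2.8-fold higher number from compound 1 to compound 3 (0.44 log units; beyond the scatter), a weakening somewhat beyond the scatter.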

Compound 3, half-maximal effective concentration: 162 nM
Estimate against measurement, compound 3: 12-fold (1.09 log units) above; the measured number lies below the stated range.
By their numbers in this assay, from the lowest: compound 3; then compound 1; then compound 2.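

In this assay, among the compounds shown here, the swap of 4-cyanobenzyl for 4-methylbenzyl gives a 4.5-fold lower number from compound 1 to compound 3 (0.65 log units; beyond the scatter) and is the first change confined to one place. This position, para to a large group, therefore responds to its substituent, and the nitrile with its hydrogen-bond acceptor is not required for a number in this range, since methyl, which has no such acceptor, gives the lower number. No measurement at hand bears on the cause of this step.

A single pair leaves open whether hydrogen, chloro, methoxy, ethyl or a longer alkyl chain at this carbon would lower the number further or raise it. It also leaves open whether 4-methylbenzyl would bring the same gain on a core with the alkene linker of compound 2.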